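The compounds below may be only part of what the source reports. "The series", "measured", "known", "first", "only" and "open" are said of these compounds alone.

Measured compounds in a functional assay on the whole organism with Rattus norvegicus as the target; on this read-out lower numbers stand for an effect already at smaller amounts and higher numbers for an effect only at larger amounts of compound:
compound 1 `CCNc1c(C)nc2c(OCc3ccccc3)cccn12`, for which compound 1 gives 3.5 mg/kg;
compound 2 `CCNc1c(C)nc2c(CCc3ccccc3)cccn12`, for which compound 2 gives 5.2 mg/kg;
compound 3 `COc1c(C)nc2c(OCc3ccccc3)cccn12`, for which compound 3 gives 3.6 mg/kg.

Compounds 1 and 3 share a core and differ in one place: methoxy in place of ethylamino on an aromatic carbon. In this assay this change made a 1.0-fold higher number from compound 1 to compound 3 (0.01 log units; within the scatter). How the core of compound 2 differs from the core of compound 1 is not broken down here; in this assay compound 2 gives 5.2 mg/kg and compound 1 gives 3.5 mg/kg, and these two values lie within the scatter of each other, as do those of compound 2 and compound 3.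

Compound 4 `COc1c(C)nc2c(CCc3ccccc3)cccn12` has not been measured. It differs from compound 2 in one place: methoxy in place of ethylamino on an aromatic carbon. The place is described in the same words as for the step from compound 1 to compound 3, so this is the same change on the core of compound 2. Because that change gave a 1.0-fold higher number from compound 1 to compound 3 (0.01 log units; within the scatter), a step of similar size is expected here, namely no change at the digits printed from compound 2 to compound 4 (within the scatter). Compound 4 is accordingly estimated at 5.2 mg/kg, with a likely range from 2.6 mg/kg to 10.4 mg/kg.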

Compound 4, dose for half-maximal effect: 20 mg/kg
For compound 4 the middle estimate is 3.8-fold (0.59 log units) below the measured one; the whole stated range lies below it.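

In this assay, methoxy in place of ethylamino on an aromatic carbon did not behave alike on the two cores, and on the core of compound 2 it gave a 3.8-fold higher number from compound 2 to compound 4 (0.59 log units; beyond the scatter). Set side by side, the two steps differ by more than the scatter of two such steps: the same change on two cores in this assay, a 1.0-fold higher number (0.01 log units; within the scatter) from compound 1 to compound 3 and a 3.8-fold higher number (0.59 log units; beyond the scatter) from compound 2 to compound 4, 3.7-fold (0.57 log units) apart, beyond the scatter of two such steps. Within the data shown here, this shows that, in this series, the size of the step seen on one core could not simply be carried over to the other, but with only two steps it does not show which feature of the cores goes with the gap, nor what the change would do on any further core.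

Only ethylamino and methoxy appear on this carbon, so the compounds shown leave open how a hydroxyl, a dimethylamino group or a longer alkoxy chain would fare there on either core. They also leave open whether the same swap would give a step of either size on a core bearing a longer chain in place of the benzyloxy group of compound 1.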